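The source may hold more compounds than are shown below. What is called first, only, known or untested is meant among the compounds shown, and "the series" means these compounds.

Three compounds share one core and differ only in the five-membered ring that sits on a saturated chain carbon bound to an aromatic carbon and a saturated chain carbon. In a functional assay on CHO cells for antagonist activity at prostaglandin E2 receptor EP3 subtype (Homo sapiens), read by cAMP accumulation (on this read-out lower numbers stand for stronger inhibition and higher numbers for weaker inhibition), compound 1 `CC(C)C(/C=C1/CCNC1=O)c1ccc(-c2ccc3cccc(F)c3c2)[nH]c1=O` gives 8.1 nM, compound 2 `Cc1nc(C(c2ccc(-c3ccc4cccc(F)c4c3)[nH]c2=O)C(C)C)[nH]c1C` gives 50 nM, and compound 3 `CC(C)C(c1cnc(N)s1)c1ccc(-c2ccc3cccc(F)c3c2)[nH]c1=O` gives 39 nM. Compound 3 holds the second highest of the three numbers: the gap a 1.3-fold lower number from compound 2 to compound 3 (0.11 log units; within the scatter) lies within the scatter, whereas a 4.8-fold higher number from compound 1 to compound 3 (0.68 log units; beyond the scatter) and a 6.2-fold higher number from compound 1 to compound 2 (0.79 log units; beyond the scatter) lie beyond it. Compound 4 `Cc1c[nH]c(C(c2ccc(-c3ccc4cccc(F)c4c3)[nH]c2=O)C(C)C)n1` has not been measured in this assay. It differs from compound 3 by 4-methyl-1H-imidazol-2-yl in place of 2-amino-1,3-thiazol-5-yl on a saturated chain carbon bound to an aromatic carbon and a saturated chain carbon. The step that bears on this is the exchange of one aromatic five-membered ring for another, which gave a 1.3-fold lower number from compound 2 to compound 3 (0.11 log units; within the scatter). The nearest relative of compound 4 is compound 2, which with its 4,5-dimethyl-1H-imidazol-2-yl gives 50 nM. The step of a 1.2-fold higher number from compound 3 to compound 4 (0.06 log units; within the scatter) is therefore expected to stay within the scatter. Compound 4 is estimated to give 45 nM in this assay, with a likely range from 18 nM to 110 nM.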

Compound 4, half-maximal inhibitory concentration: 36 nM
Compound 4: middle estimate off by 1.3-fold (0.10 log units), on the high side; the measured number falls inside the stated range.
By their numbers in this assay, from the lowest: compound 1; then compounds 4, 3 and 2 (each within the scatter of the next).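

In this assay, the methyl on the aromatic carbon of the imidazole can go without a detectable effect: hydrogen in its place gives a 1.4-fold lower number from compound 2 to compound 4 (0.14 log units; within the scatter). The imidazole with a single methyl also cannot be told apart from the aminothiazole, with a 1.1-fold lower number from compound 3 to compound 4 (0.03 log units; within the scatter), while compound 1, with its non-aromatic ring, remains separate from this simpler imidazole, with a 4.4-fold higher number from compound 1 to compound 4 (0.65 log units; beyond the scatter). No measurement shown here explains these numbers.

As far as these compounds go, it remains open whether a larger group on the imidazole, such as an ethyl or a phenyl, would keep the number where it is or shift it. From the compounds shown here alone, it is equally open whether a six-membered aromatic ring such as pyridine, or an open-chain amide, at this position would come closer to compound 1.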